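Swapping the ester group at the weak end of the series

The source may hold more compounds than are shown below. What is called first, only, known or untested is meant among the compounds shown, and "the series" means these compounds.

Measured in a functional assay on MCF7 cells (Homo sapiens) for antiproliferative activity, read by MTT assay, with a stated time of 72 h; a higher number here means a weaker inhibitor, a lower number a stronger inhibitor:
- compound 1 `CCN(CC)CCCNC(=O)c1ccc(C(CC)(CC)c2ccc(C#CC(O)(CC)CC)c(C)c2)n1CC`: 17800 nM
- compound 2 `C#CCCOC(=O)c1ccc(C(CC)(CC)c2ccc(C#CC(O)(CC)CC)c(C)c2)n1CC`: > 50000 nM (a limit)

For compound 2 the assay reports only a limit, > 50000 nM. The data so far show (the limit of > 50000 nM in this assay, at which 1 of the 2 values shown sits).

Compound 3 `CCn1c(C(=O)On2nnc3ccccc32)ccc1C(CC)(CC)c1ccc(C#CC(O)(CC)CC)c(C)c1` differs from compound 2 by a group of 9 heavy atoms (6 carbon, 3 nitrogen; one five-membered aromatic ring with 3 hetero atoms, one six-membered aromatic ring of carbon only) in place of a group of 4 heavy atoms (4 carbon; no ring), on an oxygen next to a carbonyl group. Among the compounds with values here, the one measured step at this carbonyl is an at least 2.8-fold higher number from compound 1 to compound 2 (0.44 log units; beyond the scatter), which lies beyond the scatter. It involves a different pair of groups, so it sets no size for this change. Within the data shown here, the only number in this assay clearly on the stronger side is that of compound 1, at 17800 nM, and compound 3 does not carry the group of compound 1. No step beyond the scatter is therefore expected, and the expected step is an at least 1.2-fold lower number from compound 2 to compound 3 (0.09 log units; that floor lies within the scatter). For compound 3 the estimate is 40000 nM, with an expected range of 14000 nM to 90000 nM.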

Compound 3, half-maximal inhibitory concentration: > 50000 nM
Compound 3: only a limit was reported (the forecaster's own chance of this, stated with the estimate: 55%); at least 1.2-fold (0.09 log units) between middle value and limit.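

In this assay compound 3 gives > 50000 nM, which is a limit of the assay. With the ring-bearing group in place of but-3-yn-1-yl on an oxygen next to a carbonyl group, a second, quite different ester group now sits at the same limit, and the step between these two esters cannot be read: the limit of > 50000 nM in this assay, at which 2 of the 3 values shown sit. Within the data shown here, compound 1 remains the only compound with a measured number, and the change on the carbonyl carbon gives an at least 2.8-fold higher number from compound 1 to compound 3 (0.44 log units; beyond the scatter).

On these data alone, how far either ester lies past the limit stays open. Also open, as far as these compounds go, is whether the difference from compound 1 follows the amide link or the diethylamino group, which a simple ethylamino group or a carboxylic acid on the same carbonyl carbon could help separate.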